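Replacing 1H-imidazol-4-yl with 1H-pyrrol-3-yl on the shared core

The source may report more compounds than this note shows. Statements on the series, on what has been measured and on what is new or still open speak of the compounds shown alone.

Three compounds on the shared core have gone into a functional assay on HL-60 cells (Homo sapiens) for cytotoxicity, read by XTT assay, with a stated time of 3 days; a higher number here means a weaker inhibitor, a lower number a stronger inhibitor. There, compound 1 `OC[C@H]1O[C@@H](n2cc(F)c3c(-c4nccs4)ncnc32)[C@H](O)[C@@H]1O` gives 1000 nM and compound 2 `OC[C@H]1O[C@@H](n2cc(F)c3c(-c4ccc[nH]4)ncnc32)[C@H](O)[C@@H]1O` gives 3300 nM. Compound 3 `OC[C@H]1O[C@@H](n2cc(F)c3c(-c4c[nH]cn4)ncnc32)[C@H](O)[C@@H]1O` stands as "not determined" (no result reported), as no result was reported for it, so it provides no starting value.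

The change under consideration leads to compound 4 `OC[C@H]1O[C@@H](n2cc(F)c3c(-c4cc[nH]c4)ncnc32)[C@H](O)[C@@H]1O`: 1H-pyrrol-3-yl in place of 1H-imidazol-4-yl on an aromatic carbon. The exchange is 1H-pyrrol-3-yl in place of 1H-imidazol-4-yl on an aromatic carbon of the six-membered aromatic ring of the core.

Among the measured compounds shown here, only one measured step bears on this, and only indirectly. That step, a 3.3-fold higher number from compound 1 to compound 2 (0.52 log units; beyond the scatter), is modest and involves a different pair of groups, although it does introduce a 1H-pyrrol-2-yl group. With no value for compound 3, no size or direction can be expected for the step to compound 4 in this assay. The expectation therefore rests on the two measured values, taking compound 1 at 1000 nM and compound 2 at 3300 nM as the reference points. For the measured compounds named here, no 1H-pyrrol-3-yl compound has been measured, so the range is kept wide. Compound 4 is estimated at 1800 nM, with an expected range of 400 nM to 8000 nM.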

Compound 4, half-maximal inhibitory concentration: 1900 nM
The estimate for compound 4 lay 1.1-fold (0.02 log units) below the measured number; low and high end bracket the measured number.
By their numbers in this assay, from the lowest: compounds 1, 4 and 2 (each within the scatter of the next, the first and the last beyond it).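

In this assay, 1H-pyrrol-3-yl in place of 1H-pyrrol-2-yl gives a 1.7-fold lower number from compound 2 to compound 4 (0.24 log units; within the scatter) and 1H-pyrrol-3-yl in place of 1,3-thiazol-2-yl gives a 1.9-fold higher number from compound 1 to compound 4 (0.28 log units; within the scatter) on the same aromatic carbon of the shared core. Neither new step separates compound 4 from its neighbour, although compound 1 and compound 2 do stand apart by a 3.3-fold higher number from compound 1 to compound 2 (0.52 log units; beyond the scatter), so on these numbers the position accepts the 1H-pyrrol-3-yl group without a change beyond the scatter against either earlier group. The step from compound 3 to compound 4, the exchange of 1H-imidazol-4-yl for 1H-pyrrol-3-yl, cannot be read, as compound 3 has no result, and nothing available accounts for the numbers that can be read.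

Open, from the compounds shown here alone, is whether the ring nitrogen with its hydrogen matters at this position, which a phenyl, furan-3-yl or thiophen-3-yl group would test in this assay. Also open, going by these compounds, is whether a larger substituent on the five-membered ring, such as a methyl or an aminomethyl group, would leave the numbers in the same range.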